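A few compounds are considered here, and "the series" means these few. Any claim that something is new, unique, unknown or untested is made for them only; others in the source may bear on it.

Three close relatives of one shared core have been tested in an ADME assay on NCM460 cells (Homo sapiens) for cytotoxicity, read by MTT assay, with a stated time of 72 h; on this read-out lower numbers stand for stronger inhibition and higher numbers for weaker inhibition. Compound 3 `COc1ccc(NC(=O)c2cccc(/C=C3\CC(=O)N(c4ccccc4)C3=O)c2)cc1` carries a 4-methoxyphenyl group on its amide-type nitrogen. In this assay compound 3 gives > 100000 nM, which is a limit of the assay rather than a measured number. Compound 1 `CCc1ccc(NC(=O)c2cccc(/C=C3\CC(=O)N(c4ccccc4)C3=O)c2)cc1` gives > 100000 nM, again a limit. Compound 2 `Cc1ccc(N2C(=O)C/C(=C\c3cccc(C(=O)Nc4cccc(F)c4)c3)C2=O)cc1` gives > 100000 nM, also a limit. For the measured compounds named here, the one measured step connecting two of these, a step that the two limits leave unreadable from compound 1 to compound 3, is unreadable in size because of the limit of > 100000 nM in this assay, at which 3 of the 3 values shown sit. Compound 4 `O=C(Nc1cccc(F)c1)c1cccc(/C=C2\CC(=O)N(c3ccccc3)C2=O)c1` differs from compound 3 in a single place: 3-fluorophenyl in place of 4-methoxyphenyl on an amide-type nitrogen. Compound 2 also carries a 3-fluorophenyl group on its amide-type nitrogen, yet it differs from compound 4 elsewhere too, so no single step can be read from it. What the numbers show is simply that every tested relative sits at the same limit. The expectation is therefore no change beyond the scatter, with the step from compound 3 to compound 4 estimated as a step that the limit leaves unreadable from compound 3 to compound 4. Compound 4 is expected to give about 150000 nM in this assay, with a range from 60000 nM to 400000 nM, and most likely only the limit will be reported once more.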

Compound 4, half-maximal inhibitory concentration: > 100000 nM
Compound 4: only a limit was reported (the forecaster's own chance of this, stated with the estimate: 85%); the middle value is on the limit's open side.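

No size can be read for the steps from compound 1, compound 2 or compound 3 to compound 4 in this assay, because all four compounds share one limit: the limit of > 100000 nM in this assay, at which 4 of the 4 values shown sit. The compounds shown leave open how far beyond that limit each one lies, and whether any change to the shared core would give a measurable value.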